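Hydroxy to methoxy on compound 2

The source may report more compounds than this note shows. Statements on the series, on what has been measured and on what is new or still open speak of the compounds shown alone.

In an ADME assay on THP-1 cells (Homo sapiens) for cytotoxicity, read by flow cytometry and propidium iodide staining, with a stated time of 72 h (on this read-out higher numbers stand for weaker inhibition and lower numbers for stronger inhibition), compound 1 (`CC(=O)Nc1ccc2oc(-c3ccc(F)cc3)c(O)c(=O)c2c1`) gives 26000 nM as a plain number. Compound 2 (`CC(=O)Nc1ccc2oc(-c3ccc(C(F)(F)F)cc3)c(O)c(=O)c2c1`) stands at > 50000 nM and that is a limit, not a number. Compound 3 (`Nc1ccc2oc(-c3ccc(C(F)(F)F)cc3)c(O)c(=O)c2c1`) stands at > 125000 nM and that too is a limit. Trifluoromethyl in place of fluoro on an aromatic carbon gives an at least 1.9-fold higher number from compound 1 to compound 2 (0.28 log units; that floor lies within the scatter) in this small set. Hydrogen in place of acetyl on a nitrogen on an aromatic ring gives a step that the two limits leave unreadable from compound 2 to compound 3 and so supplies no size.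

The change leading to compound 4 (`COc1c(-c2ccc(C(F)(F)F)cc2)oc2ccc(NC(C)=O)cc2c1=O`) is methyl in place of hydrogen on an oxygen on an aromatic ring and reads hydroxy to methoxy. Neither measured step touches that oxygen, so neither gives a size for this change. No step beyond the scatter is therefore expected in this assay for it, and no direction can be argued. The estimated step is a step that the limit leaves unreadable from compound 2 to compound 4 and it is expected to stay small. Compound 4 is expected at 60000 nM with an estimated range of 25000 nM to 125000 nM for now.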

Compound 4, half-maximal inhibitory concentration: > 125000 nM
Compound 4: a limit, no number; the forecaster's own chance of this, stated with the estimate: 60%; at least 2.0-fold (0.31 log units) between middle value and limit.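

Compound 2 at > 50000 nM is a limit. For the compounds shown here, compound 4 at > 125000 nM is a limit too, so no step between compound 2 and compound 4 can be read. The compounds shown leave open both the size and the direction of the hydroxy to methoxy change in this assay.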